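From 3-methoxyphenyl to 3-fluorophenyl: an expected small step

This account rests on a few compounds, and the source may have more. Where it says the series, first, only, none or still open, it means among the compounds named here.

In a functional assay on M21 cells (Homo sapiens) for antiproliferative activity, read by sulforhodamine B assay, with a stated time of 48 h (on this read-out higher numbers stand for weaker inhibition and lower numbers for stronger inhibition), compound 3 (`CCN1CCN(c2ccc(S(=O)(=O)Oc3cccc(OC)c3)cc2)C1=O`) gives 7000 nM, which is within the scatter of compound 1 (`CN1CCN(c2ccc(S(=O)(=O)Oc3cccc(F)c3)cc2)C1=O`) at 5800 nM. Compound 2 (`CCN1CCN(c2ccc(S(=O)(=O)Oc3ccccc3OC)cc2)C1=O`) gives > 100000 nM, and this is a limit of the assay.

Compound 4 (`CCN1CCN(c2ccc(S(=O)(=O)Oc3cccc(F)c3)cc2)C1=O`) has fluoro in place of methoxy on an aromatic carbon of compound 3, meta to a large group: fluoro in place of methoxy on an aromatic carbon. Among the measured compounds shown here, only one measured step bears on this change, and only indirectly. The large step of an at least 14-fold lower number from compound 2 to compound 3 (1.15 log units; beyond the scatter) goes from 2-methoxyphenyl to 3-methoxyphenyl, and compound 4 keeps the substituent in the place it has in compound 3. That step exchanges no methoxy for fluoro, however, so the better guide is compound 1, which carries 3-fluorophenyl and gives 5800 nM, in line with compound 3. No change beyond the scatter is therefore expected. The estimated change is a 1.2-fold lower number from compound 3 to compound 4 (0.07 log units; within the scatter). Compound 4 is expected at about 6000 nM, within an estimated range of 2500 nM to 15000 nM.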

Compound 4, half-maximal inhibitory concentration: 11000 nM
The estimate for compound 4 lay 1.8-fold (0.26 log units) below the measured number; low and high end bracket the measured number.
By their numbers in this assay, from the lowest: compounds 1, 3 and 4 (each within the scatter of the next). At a limit, above all of these: compound 2.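

In this assay, the direct exchange of methoxy for fluoro on the aromatic carbon changes little: a 1.6-fold higher number from compound 3 to compound 4 (0.20 log units; within the scatter). The methyl in place of hydrogen on the saturated chain carbon also stays small: a 1.9-fold higher number from compound 1 to compound 4 (0.28 log units; within the scatter). Together with 3-fluorophenyl in place of 2-methoxyphenyl, which gives an at least 9.0-fold lower number from compound 2 to compound 4 (0.95 log units; beyond the scatter), these steps show that fluoro serves as well as methoxy here, and that the second large step from compound 2 again starts from a limit, not a number: the limit of > 100000 nM in this assay, at which 1 of the 4 values shown sits.

Going by these compounds, whether a chloro group, a nitrile or an amine at the same place would stay in this range remains open. A 2-fluorophenyl compound would show whether the large gap from compound 2 follows the place of the substituent or the methoxy group itself.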